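A few compounds are considered here, and "the series" means these few. Any claim that something is new, unique, unknown or untested is made for them only; others in the source may bear on it.

In a functional assay on T-24 cells (Homo sapiens) for cytotoxicity, read by colorimetric assay and MTT assay (on this read-out higher numbers stand for weaker inhibition and lower numbers for stronger inhibition), compound 1 (`CCN(CC)C(=O)Cn1c(=O)c(-c2ccc(OC)cc2)cc2c(OC)cc(OC)cc21`) gives 10000 nM and compound 2 (`COc1ccc(-c2cc3c(OC)cc(OC)cc3n(CC(=O)OCc3ccccc3)c2=O)cc1`) gives 10000 nM on the same scale. Compound 3 (`COc1cc(OC)c2cc(-c3ccc(O)cc3)c(=O)n(C)c2c1`) gives 10000 nM and so stands level with both of them. None of the three sets itself apart, which leaves little to separate them on these numbers.

The next compound to be tested is compound 4 (`COc1cc(OC)c2cc(-c3ccc(OC(C)=O)cc3)c(=O)n(C)c2c1`), which is compound 3 with a single change: acetyl in place of hydrogen on an oxygen on an aromatic ring. In plain terms, an acetyl takes the place of the hydrogen on an oxygen on an aromatic ring, turning hydroxy into acetoxy.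

Going by the values given here, no measured pair shows this exact change. Among the compounds with values here, the only measured step between compounds differing in one place is no change at the digits printed from compound 1 to compound 2 (within the scatter), where benzyloxy replaces diethylamino on a carbonyl carbon. That step lies elsewhere in the structure, so it is only indirect evidence, but it does show one structural swap leaving the reading unmoved. The value of compound 3 at 10000 nM offers no hint of a shift either. What is expected in this assay is therefore no change at the digits printed from compound 3 to compound 4 (within the scatter), with no direction favoured and nothing beyond the usual scatter. Compound 4 is expected to read 10000 nM (estimated range 4000 nM to 20000 nM).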

Compound 4, half-maximal inhibitory concentration: 10000 nM
For compound 4 middle estimate and measured number coincide at the digits printed; the measured number falls inside the stated range.
By their numbers in this assay, from the lowest: compounds 1, 2, 3 and 4 (each within the scatter of the next).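

In this assay, going by these compounds alone, the step on the oxygen on an aromatic ring reads no change at the digits printed from compound 3 to compound 4 (within the scatter) and gives the first direct look at this position, since the only earlier step concerned a different part of the structure. Turning hydroxy into acetoxy removes the hydrogen on that oxygen, and the reading stays where it stands for compound 3 at 10000 nM, so in this assay the change brings no stronger inhibition of the cells. Nothing on hand gives a reason for this flat result.

Within the data shown here, all four compounds now share a single reading, so the series offers no stronger compound against which the effect of any group could be judged. As far as these compounds go, it remains open whether a different group on that oxygen, such as a longer chain ending in an amine or in a carboxylic acid, would move the reading in either direction, and whether the same change would behave alike on a compound carrying other groups on the shared core.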